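Chloro in place of hydrogen: from compound 3 to compound 4

The compounds below may be only part of what the source reports. "The series", "measured", "known", "first", "only" and "open" are said of these compounds alone.

Measured so far:
- compound 1, `CC(=O)SCCC(CCCCC(=O)Nc1ccccc1)SC(C)=O`, gives 7.24% in a functional assay on KB cells (Homo sapiens) for inhibition, read by MTT assay, with a stated time of 24 h, tested at 0.1 ug/mL; a lower number here means less inhibition of growth, a higher number more inhibition of growth at the concentration tested
- compound 2, `CC(=O)SCCC(CCCCC(=O)Nc1ccc(Cl)cc1)SC(C)=O`, gives 11.4% in this assay
- compound 3, `O=C(CCCCC(CCSC(=O)c1ccccc1)SC(=O)c1ccccc1)Nc1ccccc1`, gives 1.52% in this assay

Compound 2 differs from compound 1 by chloro in place of hydrogen on an aromatic carbon, and the step is a number 4.2 percentage points higher from compound 1 to compound 2 (within the scatter). Compound 3 stands on another core; the difference between the two cores is not broken down here. The three numbers lie within the usual scatter of one another, so no order among them is claimed.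

Compound 4, `O=C(CCCCC(CCSC(=O)c1ccccc1)SC(=O)c1ccccc1)Nc1ccccc1Cl`, is not yet measured. It differs from compound 3 by chloro in place of hydrogen on an aromatic carbon. This is the same kind of change as from compound 1 to compound 2, not the same: there the chloro sits para to a large group, here ortho to a large group.

For compound 4 in this assay a step of a number 3.5 percentage points higher from compound 3 to compound 4 (within the scatter) is expected, beside a number 4.2 percentage points higher from compound 1 to compound 2 (within the scatter), because a number 4.2 percentage points higher from compound 1 to compound 2 (within the scatter) stayed within the scatter. The estimate for compound 4 is 5%, expected to fall between 0% and 13%.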

Compound 4, percent growth inhibition at one concentration: 3.62%
Compound 4: middle estimate off by 1.4 percentage points, on the high side; measured number inside the range.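

In this assay, chloro in place of hydrogen gives a number 2.1 percentage points higher from compound 3 to compound 4 (within the scatter), and beside the step on the other core it shows no difference: the same change on two cores in this assay, a number 4.2 percentage points higher (within the scatter) from compound 1 to compound 2 and a number 2.1 percentage points higher (within the scatter) from compound 3 to compound 4, 2.1 percentage points apart, within the scatter of two such steps. The change therefore reads alike on both cores, but neither step lies beyond the scatter, so this agreement shows no measurable effect of chloro on either core. It also cannot separate core from position, since the chloro of compound 4 is ortho to a large group while that of compound 2 sits elsewhere on the ring.

Still open, on these data alone, is whether an amine or a carboxylic acid in place of the chloro, or a longer chain in place of the present one, would shift the number beyond the scatter.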